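Thiophen-2-yl to thiophen-3-yl: working notes

A few compounds are considered here, and "the series" means these few. Any claim that something is new, unique, unknown or untested is made for them only; others in the source may bear on it.

- compound 1 `Oc1cccc(-c2cc(-c3ccccc3)nc(-c3ccccc3)c2)c1`: 19500 nM
- compound 2 `Oc1cccc(-c2cc(-c3ccccc3)nc(-c3cccs3)c2)c1`: 17700 nM

Both values come from a functional assay on MDA-MB-231 cells (Homo sapiens) for cytotoxicity, read by ELISA, with a stated time of 2 days; on this read-out lower numbers stand for stronger inhibition and higher numbers for weaker inhibition. There, compound 2 gives 17700 nM, which lies within the scatter of compound 1, so the two cannot be ranked.

The next compound to be measured is compound 3 `Oc1cccc(-c2cc(-c3ccccc3)nc(-c3ccsc3)c2)c1`. Its difference from compound 2 is thiophen-3-yl in place of thiophen-2-yl on an aromatic carbon. Thiophen-3-yl takes the place of thiophen-2-yl on an aromatic carbon, next to the ring nitrogen.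

Among the compounds with values here, the one measured step that bears on this is a 1.1-fold lower number from compound 1 to compound 2 (0.04 log units; within the scatter), where thiophen-2-yl replaced phenyl. That step stayed within the scatter, so no shift beyond the scatter is expected in this assay, and no direction can be assigned. Within the data shown here, no measurement yet covers thiophen-3-yl itself.

The expected step is a 1.0-fold higher number from compound 2 to compound 3 (0.01 log units; within the scatter). The estimate for compound 3 is 18000 nM, with an expected range of 10000 nM to 32000 nM.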

Compound 3, half-maximal inhibitory concentration: 19000 nM
Compound 3: middle estimate off by 1.1-fold (0.02 log units), on the low side, within the range that was stated.
By their numbers in this assay, from the lowest: compounds 2, 3 and 1 (each within the scatter of the next).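

In this assay the shift of the attachment point within the thiophene gives a 1.1-fold higher number from compound 2 to compound 3 (0.03 log units; within the scatter) and the exchange of phenyl for thiophen-3-yl gives a 1.0-fold lower number from compound 1 to compound 3 (0.01 log units; within the scatter). At this position, next to the ring nitrogen, the two thiophene attachments therefore cannot be told apart, and neither thiophene can be ranked against phenyl in this assay; all three aromatic rings give the same result within the scatter. No available evidence bears on why these values do not separate.

Every group shown at this position is an aromatic ring, so the effect of an amine, a carboxylic acid or a longer alkyl chain there remains open. Also open, going by these compounds, is whether this insensitivity would persist with the 3-hydroxyphenyl group replaced by, for example, a 3-aminophenyl group.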